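The compounds below may be only part of what the source reports. "The series", "measured", "known", "first", "only" and "open" are said of these compounds alone.

Compound 1 `CCN(CC)CCCn1c(=O)c(=Cc2ccc(F)c(F)c2)s/c1=C1\C(=O)Nc2cc(F)ccc21`: 1120 nM
Compound 2 `CCN(CC)CCCn1c(=O)c(=Cc2ccc(F)c(F)c2)s/c1=C1\C(=O)Nc2ccc(F)cc21`: 1300 nM

In a functional assay on NCI-H460 cells (Homo sapiens) for inhibition, read by MTT assay, with a stated time of 72 h (on this read-out higher numbers stand for weaker inhibition and lower numbers for stronger inhibition), compound 1 gives 1120 nM and compound 2 gives 1300 nM. Compound 2 carries the higher of the two numbers, yet the gap to compound 1 lies within the scatter, so the two compounds stand level and neither can be called the weaker inhibitor. Both share one core and one side chain on the aromatic nitrogen; they differ only in where the fluorine sits on the bicyclic part.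

Compound 3 `CN(C)CCn1c(=O)c(=Cc2ccc(F)c(F)c2)s/c1=C1\C(=O)Nc2ccc(F)cc21` keeps the core and fluorine pattern of compound 2 and changes the side chain: dimethylamino in place of (diethylamino)methyl on a saturated chain carbon, two bonds along the chain from an aromatic nitrogen. Within the data shown here, no measured pair shows what such a change does here, so no step beyond the scatter is expected in this assay from this change alone. Compound 3 is therefore estimated to land near compound 2, at about 1500 nM, with a likely range from 700 nM to 3500 nM, which means an expected step of a 1.2-fold higher number from compound 2 to compound 3 (0.06 log units; within the scatter).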

Compound 3, half-maximal inhibitory concentration: 44700 nM
Compound 3: middle estimate off by 30-fold (1.47 log units), on the low side; the whole stated range lies below it.
By their numbers in this assay, from the lowest: compounds 1 and 2 (each within the scatter of the next); then compound 3.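

The side chain on the aromatic nitrogen carries far more weight here than the place of a fluorine, which left compound 1 and compound 2 level. In this assay, the change to the side chain gives a 34-fold higher number from compound 2 to compound 3 (1.54 log units; beyond the scatter), so inhibition is largely lost. Read one bond further out, the same change is 3-(diethylamino)propyl to 2-(dimethylamino)ethyl, so chain length and amine end change together, and no measured data explain the loss.

Still open, on these data alone, is which of these two changes drives the step: a 3-(dimethylamino)propyl chain would keep the chain of compound 2 with the new amine end, and a 2-(diethylamino)ethyl chain would do the reverse. Also open, as far as these compounds go, is whether a morpholine at the chain end, or a carboxylic acid there, would keep the inhibition of compound 2.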